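This account rests on a few compounds, and the source may have more. Where it says the series, first, only, none or still open, it means among the compounds named here.

In an assay on isolated protein for inhibition of protein kinase C zeta type (Homo sapiens), read by mobility shift assay, tested at 30 uM (on this read-out higher numbers stand for more inhibition at the one concentration tested (going by the name of the read-out) and lower numbers for less inhibition), the measured compounds gave these results:
Compound 1 `Cc1cc2c(c(N)nn2C)c(=O)[nH]1`: 0%
Compound 2 `Cn1nc(N)c2c(=O)[nH]c(-c3ccccc3)cc21`: 6%
Compound 3 `COCCNc1nc(C)cc2c1c(N)nn2C`: -10%

Compound 2 differs from compound 1 in one place: phenyl in place of methyl on an aromatic carbon. That change made the step of a number 6 percentage points higher from compound 1 to compound 2 (within the scatter). Compound 4 `COCCNc1nc(-c2ccccc2)cc2c1c(N)nn2C` has not been measured; it stands to compound 3 as compound 2 stands to compound 1: phenyl in place of methyl on an aromatic carbon. The difference between the two cores, that of compound 1 and that of compound 3, is not broken down here. The surroundings of the place are not identical either: in compound 1 the carbon is meta to a group of 1 heavy atom, whereas in compound 3 it is meta to a (2-methoxyethyl)amino group (5 heavy atoms), so this is the same kind of change rather than the same one. The values of compound 3 and compound 2 lie beyond the scatter of each other, compound 3 being lower, while compound 3 and compound 1 lie within it. Because the earlier step of a number 6 percentage points higher from compound 1 to compound 2 (within the scatter) stayed within the scatter, a step of similar size, a number 6 percentage points higher from compound 3 to compound 4 (within the scatter), is expected here. Compound 4 is therefore estimated at -4%, with a likely range from -16% to 8%.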

Compound 4, a percentage reported as inhibition, at one concentration (the size of the read-out at that concentration, not a potency): 20%
For compound 4 the middle estimate is 24 percentage points below the measured one, outside the stated range (above it).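

In this assay, phenyl in place of methyl on an aromatic carbon gave a number 30 percentage points higher from compound 3 to compound 4 (beyond the scatter), a clear step on the core of compound 3. The change did not carry over from one core to the other with the same size: the same change on two cores in this assay, a number 6 percentage points higher (within the scatter) from compound 1 to compound 2 and a number 30 percentage points higher (beyond the scatter) from compound 3 to compound 4, 24 percentage points apart, beyond the scatter of two such steps These two pairs show that the size of this step depends on the surroundings, but they do not show which difference between the cores is responsible, and they give no rule for a third core; compound 4 at 20% is also a reading at one concentration, not a potency.

The compounds shown leave open whether the larger step on the core of compound 3 is tied to the (2-methoxyethyl)amino group, for instance whether it would persist if a longer chain ending in an amine stood there instead. They also leave open whether a group smaller than phenyl, such as ethyl, would already give part of this step.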